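Fluoro for methoxy where every value is a limit

A few compounds are considered here, and "the series" means these few. Any claim that something is new, unique, unknown or untested is made for them only; others in the source may bear on it.

Compound 1 `COc1cc(-c2ncnn2-c2ccc(Cl)cc2Cl)cc(OC)c1OC` gives > 10000 nM as a limit
Compound 2 `COc1cccc(-c2ncnn2-c2cc(OC)c(OC)c(OC)c2)c1` gives > 10000 nM as a limit
Compound 3 `COc1cc(-c2ncnn2-c2ccc(F)cc2)cc(OC)c1OC` gives > 10000 nM as a limit

In a functional assay on K562 cells (Homo sapiens) for antiproliferative activity, read by MTT assay, with a stated time of 72 h (on this read-out lower numbers stand for stronger inhibition and higher numbers for weaker inhibition), compound 2 stands at > 10000 nM and this is a limit, not a number. Among the measured compounds shown here, the wider picture is the limit of > 10000 nM in this assay, at which 3 of the 3 values shown sit, and so no compound can be ranked against another.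

Compound 4 `COc1cc(-n2ncnc2-c2cccc(F)c2)cc(OC)c1OC` keeps the core of compound 2 and alters one group. The change is fluoro in place of methoxy on an aromatic carbon and, in short, it puts fluoro in place of methoxy on an aromatic carbon, turning 3-methoxyphenyl into 3-fluorophenyl.

For the measured compounds named here, the only measured step is a step that the two limits leave unreadable from compound 1 to compound 3 and its size cannot be read. It also concerns a different group, so it offers no size to carry over to this change. No shift beyond the usual scatter can therefore be argued in either direction in this assay for this swap. The expectation rests on compound 2 at > 10000 nM as a limit. The estimated step is a step that the limit leaves unreadable from compound 2 to compound 4 and its direction remains uncertain. For compound 4 the estimated value is 15000 nM with an expected range from 3000 nM to 50000 nM and the assay may well report only a limit again.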

Compound 4, half-maximal inhibitory concentration: > 10000 nM
Compound 4: a limit, no number; the forecaster's own chance of this, stated with the estimate: 80%; the middle value does not contradict the limit.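

Compound 2 and compound 4 both end at a limit rather than a number in this assay, so no step between them can be read: the limit of > 10000 nM in this assay, at which 4 of the 4 values shown sit.

The compounds shown leave open how these four rank against one another, and whether any change to the shared core would give a measurable value in this assay.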